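Replacing the indole carboxylic acid with a small pyrimidine

The source may report more compounds than this note shows. Statements on the series, on what has been measured and on what is new or still open speak of the compounds shown alone.

Of the compounds shown here, three sharing one core have been tested in a functional assay on DU-145 cells (Homo sapiens) for inhibition, read by trypan blue exclusion, with a stated time of 72 h; on this read-out higher numbers stand for weaker inhibition and lower numbers for stronger inhibition. Compound 1, `Cn1c(=O)c(S(=O)(=O)c2ccc(F)cc2F)cc2cnc(Nc3ccc4[nH]c(C(=O)O)cc4c3)nc21`, is the weakest inhibitor of the group in this assay, with a value of 10000 nM. Compound 2, `CN1CCN(c2ccc(Nc3ncc4cc(S(=O)(=O)c5ccc(F)cc5F)c(=O)n(C)c4n3)cc2)CC1`, gives 5000 nM in this assay, a number that lies within the usual scatter of compound 1, so the two cannot be told apart. Compound 3, `Cn1c(=O)c(S(=O)(=O)c2ccc(Cl)cc2Cl)cc2cnc(Nc3ccc4[nH]ccc4c3)nc21`, gives 1000 nM in this assay, which lies clearly beyond the scatter from compound 1 and marks it as the stronger of the two.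

Compound 4, `Cn1c(=O)c(S(=O)(=O)c2ccc(F)cc2F)cc2cnc(Nc3ccncn3)nc21`, has not yet been measured. It differs from compound 1 in one place: pyrimidin-4-yl in place of 2-carboxy-1H-indol-5-yl on a nitrogen on an aromatic ring. Going by the values given here, no pair of measured compounds shows this exact change, so no direct step can be used as a guide. Compound 1 already sits at the weak end of what this assay can report, and the loss of both hydrogen-bond donors of the departing group gives no reason to expect a gain. The step in this assay is therefore expected to be small, either none beyond the scatter or a modest move towards weaker inhibition, as a 1.5-fold higher number from compound 1 to compound 4 (0.18 log units; within the scatter). On that basis compound 4 is estimated at 15000 nM, with a plausible range from 4000 nM to 50000 nM, and a fair chance that only a limit is reported.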

Compound 4, half-maximal inhibitory concentration: 50000 nM
For compound 4 the middle estimate is 3.3-fold (0.52 log units) below the measured one, and the stated range covers the measured number.
By their numbers in this assay, from the lowest: compound 3; then compounds 2 and 1 (each within the scatter of the next); then compound 4.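

In this assay, placing pyrimidin-4-yl in place of 2-carboxy-1H-indol-5-yl on the nitrogen gives a 5.0-fold higher number from compound 1 to compound 4 (0.70 log units; beyond the scatter), which shows that inhibition can still weaken from the already high number of compound 1. Going by these compounds alone, the earlier compounds offered no step between structures differing in one place, so this is the first direct reading of a change at this position with the rest of the molecule held constant. The change replaces a two-ring group of 12 heavy atoms and 2 hydrogen-bond donors with a single ring of 6 heavy atoms and 0 donors, but no measurement here separates these differences or explains the loss of inhibition.

The compounds shown leave open whether the loss follows from removing the carboxylic acid, from losing the two-ring group, or from both, and a 1H-indol-5-yl group without the acid on the core of compound 1 would help to separate these. They also leave open whether the small ring can be improved, as a pyrimidin-4-yl group carrying an amine on a short chain would test.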